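The compounds below may be only part of what the source reports. "The series", "measured", "known", "first", "only" and "open" are said of these compounds alone.

Measured in a functional assay on K562 cells (Homo sapiens) for cytotoxicity, read by MTT assay, with a stated time of 48 h; on this read-out lower numbers stand for stronger inhibition and higher numbers for weaker inhibition:

- compound 1 `COc1ccc(-c2c(-c3cc(OC)c(OC)c(OC)c3)noc2N)cc1OC`: 1270 nM
- compound 2 `COc1ccc(-c2c(-c3cc(OC)c(OC)c(OC)c3)noc2NC(C)=O)cc1`: 380 nM

Of these two, compound 2 has the lower number, and its gap to compound 1 lies beyond the scatter. The next compound to consider is compound 3 `COc1ccc(-c2c(-c3cc(OC)c(OC)c(OC)c3)noc2NC(C)=O)cc1OC`. Its difference from compound 2 is methoxy in place of hydrogen on an aromatic carbon, which turns 4-methoxyphenyl into 3,4-dimethoxyphenyl. Among the compounds with values here, no measured pair isolates this change. Compound 1, which also bears 3,4-dimethoxyphenyl, gives 1270 nM, but it differs from compound 3 elsewhere as well and is only a weak guide. In this assay, a small move toward a higher number is therefore expected, not clearly beyond the scatter. The expected step is a 1.6-fold higher number from compound 2 to compound 3 (0.20 log units; within the scatter). For compound 3 the estimated value is 600 nM, with an expected range of 180 nM to 1800 nM.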

Compound 3, half-maximal inhibitory concentration: 3710 nM
Compound 3: middle estimate off by 6.2-fold (0.79 log units), on the low side; measured number above the stated range.
By their numbers in this assay, from the lowest: compound 2; then compound 1; then compound 3.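

In this assay, the added methoxy, ortho to a methoxy group on the aromatic ring, proves far from neutral: it brings a 9.8-fold higher number from compound 2 to compound 3 (0.99 log units; beyond the scatter) and thus marks this position as sensitive to the change from 4-methoxyphenyl to 3,4-dimethoxyphenyl. Within the data shown here, with 3,4-dimethoxyphenyl held fixed, acetyl in place of hydrogen on the nitrogen gives a 2.9-fold higher number from compound 1 to compound 3 (0.47 log units; beyond the scatter), the first reading of that change alone, and here it goes toward the higher number. The data shown offer no measurement that would explain either step.

As far as these compounds go, it remains open whether a hydroxy group or a fluorine atom in the same place would be tolerated any better than methoxy. Also open, from the compounds shown here alone, is how acetyl on the nitrogen would compare with a longer acyl chain such as butanoyl, or how the free amine would fare alongside 4-methoxyphenyl.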